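The source may report more compounds than this note shows. Statements on the series, on what has been measured and on what is new or still open speak of the compounds shown alone.

Measured so far:
compound 1, `C=C1C(=O)O[C@H]2CC[C@@H](C)CC[C@@H]12`, gives 69% in a functional assay on P388 cells (Mus musculus) for inhibition, with a stated time of 48 h, tested at 1 ug/mL; on this read-out lower numbers stand for a weaker effect and higher numbers for a stronger effect at the one concentration tested.
compound 2, `C=C1C(=O)O[C@H]2[C@@H](O)CCCC[C@@H]12`, gives 40% in this assay.

Of the two compounds measured, compound 2 stands lowest, and the gap to compound 1 lies beyond the scatter. The step to compound 3, `C=C1C(=O)O[C@H]2[C@@H](OC(C)=O)CCCC[C@@H]12`, changes one place: acetyl in place of hydrogen on an oxygen on a saturated carbon. For the measured compounds named here, no step between measured compounds shows what such a change does, so the expected change from compound 2 to compound 3, a number 10 percentage points higher from compound 2 to compound 3 (within the scatter), is a modest rise that may still fall within the scatter. Compound 3 is therefore expected to give about 50% in this assay, within a range from 25% to 75%.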

Compound 3, a percentage reported as activity, at one concentration (the size of the read-out at that concentration, not a potency): 21%
Estimate against measurement, compound 3: 29 percentage points above, and the stated range ends above it.
By their numbers in this assay, from the lowest: compound 3; then compound 2; then compound 1.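

For the compounds shown here, putting acetyl in place of the hydrogen on this oxygen is the first single change that can be read in this assay, and it gives a number 19 percentage points lower from compound 2 to compound 3 (beyond the scatter). The effect at this one concentration therefore depends on what sits on the oxygen, and hydroxy to acetoxy lowers it rather than raising it. Nothing at hand explains why the number falls.

On these data alone, it remains open whether a methyl ether, a longer acyl chain such as butanoyl, or an amine at this place would lower the number too. A single step cannot show whether any group here can raise it.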